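Fluoro added to the chlorophenyl amide of compound 3

This account rests on a few compounds, and the source may have more. Where it says the series, first, only, none or still open, it means among the compounds named here.

Measured so far in an ADME assay on MT2 cells (Homo sapiens) for cytotoxicity, read by XTT assay, with a stated time of 4 days; a lower number here means that less compound is tolerated, a higher number that more compound is tolerated:
Compound 1 `Cc1nc(C(NC(=O)C(=O)Nc2ccc(F)cc2)C2CCCCN2)sc1CCO` gives 109000 nM.
Compound 2 `Cc1nc(C(NC(=O)C(=O)Nc2ccc(F)cc2F)C2CCCCN2)sc1CCO` gives > 105000 nM, a limit of the assay.
Compound 3 `Cc1nc(C(NC(=O)C(=O)Nc2ccc(Cl)cc2)C2CCCCN2)sc1CCO` gives > 62000 nM, also a limit of the assay.

Compound 3 thus stands only at a limit in this assay, and one of the other two values shown is a limit as well. Compound 4 `Cc1nc(C(NC(=O)C(=O)Nc2ccc(Cl)c(F)c2)C2CCCCN2)sc1CCO`, not yet measured, differs from compound 3 by fluoro in place of hydrogen on an aromatic carbon.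

Among the measured compounds shown here, the one measured step of the same kind, a step that the limit leaves unreadable from compound 1 to compound 2, cannot be sized because the limit of > 105000 nM in this assay, at which 1 of the 3 values shown sits, sits at its far end. The step that the limit leaves unreadable from compound 1 to compound 3 is likewise unreadable because the limit of > 62000 nM in this assay, at which 1 of the 3 values shown sits, closes it off, and a step that the two limits leave unreadable from compound 2 to compound 3 runs between two limits. No readable step therefore bears on the change to compound 4, and the three values show no separation beyond the scatter.

Compound 4 is expected to remain at the upper edge of the assay, with a step that the limit leaves unreadable from compound 3 to compound 4, in other words none beyond the scatter. The estimate for compound 4 is 80000 nM, from 40000 nM to 200000 nM, and a limit rather than a number is the likelier report.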

Compound 4, half-maximal cytotoxic concentration: > 41000 nM
Compound 4 gave a limit, no number; the forecaster's own chance of this, stated with the estimate: 70%; the middle value is on the limit's open side.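

No step from compound 1, compound 2 or compound 3 to compound 4 can be read in this assay, because compound 4 also gives only a limit: the limit of > 41000 nM in this assay, at which 1 of the 4 values shown sits.

The compounds shown leave open whether fluoro in place of hydrogen on an aromatic carbon, or any other change among these four compounds, shifts the half-maximal cytotoxic concentration at all.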